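A few compounds are considered here, and "the series" means these few. Any claim that something is new, unique, unknown or untested is made for them only; others in the source may bear on it.

Compound 1 `O=C1C=C[C@@H](OCc2ccccc2)[C@@H]([C@@H](COC(=O)/C=C/c2ccccc2)OCc2ccccc2)O1`: 4970 nM
Compound 2 `O=C1C=C[C@@H](OCc2ccccc2)[C@@H]([C@@H](COC(=O)/C=C/c2ccc(F)cc2)OCc2ccccc2)O1`: 3580 nM

For the measured compounds named here, compound 2 stands at the lowest of the two numbers so far obtained in a functional assay on MDA-MB-231 cells (Homo sapiens) for antiproliferative activity, read by MTT assay, with a stated time of 6 days; on this read-out higher numbers stand for weaker inhibition and lower numbers for stronger inhibition. Going by the values given here, its only neighbour is compound 1, and the step of a 1.4-fold lower number from compound 1 to compound 2 (0.14 log units; within the scatter) lies within the scatter, so the two compounds cannot be told apart on this read-out. Compound 3 `O=C1C=C[C@@H](OCc2ccccc2)[C@@H]([C@@H](COC(=O)/C=C/c2ccc([N+](=O)[O-])cc2)OCc2ccccc2)O1` has not yet been measured in this assay. It differs from compound 2 in one place: nitro in place of fluoro on an aromatic carbon. Among the compounds with values here, only one measured step touches the same aromatic carbon, namely a 1.4-fold lower number from compound 1 to compound 2 (0.14 log units; within the scatter), and that step was within the scatter. No measured step in this series involves a nitro group, so nothing shown speaks directly to this exchange. On the evidence available, the step to compound 3 is expected to remain within the scatter, with an estimated change of a 1.1-fold lower number from compound 2 to compound 3 (0.05 log units; within the scatter). Within the data shown here, compound 3 is therefore estimated at 3200 nM in this assay, with a range from 1200 nM to 8500 nM, the width of the range reflecting how little the single relevant step constrains the outcome.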

Compound 3, half-maximal inhibitory concentration: 1550 nM
Estimate against measurement, compound 3: 2.1-fold (0.31 log units) above, within the range that was stated.
By their numbers in this assay, from the lowest: compound 3; then compounds 2 and 1 (each within the scatter of the next).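

In this assay, nitro in place of fluoro on the aromatic carbon para to a large group gives a 2.3-fold lower number from compound 2 to compound 3 (0.36 log units; beyond the scatter), and nitro in place of hydrogen on that carbon gives a 3.2-fold lower number from compound 1 to compound 3 (0.51 log units; beyond the scatter), so compound 3 stands apart from both of the other compounds. With only hydrogen and fluoro at this position, no difference could be read, whereas these two modest steps show that the number does respond to the group placed there, and that the 4-nitrophenyl compound differs from the 4-fluorophenyl compound in a way that the 4-fluorophenyl compound does not differ from its unsubstituted parent. No measurement shown here accounts for why nitro behaves differently from fluoro and hydrogen.

For the compounds shown here, with only three groups compared on one carbon, it remains open whether a nitrile, an amine or a carboxylic acid on the same carbon would follow nitro, stay with fluoro and hydrogen, or go beyond both. From the compounds shown here alone, it is also open whether nitro would give a similar step on another carbon of the ring, or whether the step would hold on cells other than those of this assay.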